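Replacing the 2-aminophenyl group of compound 2 with hydroxy

The compounds below may be only part of what the source reports. "The series", "measured", "known", "first", "only" and "open" are said of these compounds alone.

Compound 1 (`C#Cc1cccc(Nc2ncnc3ccc(NC(=O)c4ccc(C(=O)Nc5ccccc5N)nc4)cc23)c1`): 21500 nM
Compound 2 (`C#Cc1cccc(Nc2ncnc3ccc(S(=O)(=O)n4ccc(/C=C/C(=O)Nc5ccccc5N)c4)cc23)c1`): 3450 nM

Both numbers come from a functional assay on HeLa cells (Homo sapiens) for cytotoxicity, read by resazurin assay (a higher number here means a weaker inhibitor, a lower number a stronger inhibitor), and these two compounds are the only ones with a result so far. Compound 2, at 3450 nM in this test, has the lower number of the pair, and its gap to compound 1 lies beyond the usual scatter of repeat measurements.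

The next compound is compound 3 (`C#Cc1cccc(Nc2ncnc3ccc(S(=O)(=O)n4ccc(/C=C/C(=O)NO)c4)cc23)c1`). It has hydroxy in place of 2-aminophenyl on an amide-type nitrogen and is otherwise the same as compound 2. Going by the values given here, no measured pair shows this change, so the expectation is a judgement from the structural change alone, and its uncertainty is wide. A step to a lower number in this assay is expected, meaning a stronger inhibitor, and one beyond the scatter. The estimated change is a 4.9-fold lower number from compound 2 to compound 3 (0.69 log units; beyond the scatter) (an expectation, not a measurement). For compound 3 the expected value is 700 nM with an estimated range from 120 nM to 3500 nM in this test.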

Compound 3, half-maximal inhibitory concentration: 500 nM
For compound 3 the middle estimate is 1.4-fold (0.15 log units) above the measured one; low and high end bracket the measured number.
By their numbers in this assay, from the lowest: compound 3; then compound 2; then compound 1.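

Going by these compounds alone, this is the first pair that differs in only one place, so a change in this assay can be tied to a single swap: compounds 1 and 2 differ in more than one place and could not do this. On the amide-type nitrogen, hydroxy in place of 2-aminophenyl gives a 6.9-fold lower number from compound 2 to compound 3 (0.84 log units; beyond the scatter), so in this pair the six-membered aromatic ring is not needed for a low number, and a group of one heavy atom does better than one of seven, even though the counts of hydrogen-bond donors and acceptors stay the same. Nothing available here explains why the number falls, and this single pair cannot separate the loss of the ring from the arrival of the hydroxy group.

Going by these compounds, it remains open how a methoxy group, a plain hydrogen or a simple amine on the same nitrogen would compare with hydroxy, and whether a carboxylic acid could stand in for the whole hydroxycarbamoyl group. On these data alone, it is also open whether the same swap would lower the number on the core of compound 1, and whether this cell result reflects the same effect in other cell types.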